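Adding a chloro group to compound 2

A few compounds are considered here, and "the series" means these few. Any claim that something is new, unique, unknown or untested is made for them only; others in the source may bear on it.

In a functional assay on B16-F10 cells (Mus musculus) for antiproliferative activity, read by MTT assay, with a stated time of 48 h (a higher number here means a weaker inhibitor, a lower number a stronger inhibitor), compound 1 (`O=C(/C=C/c1ccc(Cl)cc1)Nc1cc(-c2ccccc2)[nH]n1`) gives 1270 nM and compound 2 (`O=C(/C=C/c1ccccc1)Nc1cc(-c2ccc(Br)cc2)[nH]n1`) gives 1270 nM, so compound 2 stands level with compound 1, within the scatter. Compound 3 (`O=C(/C=C/c1ccc(Cl)cc1)Nc1cc(-c2ccc(Br)cc2)[nH]n1`) differs from compound 2 in one place: chloro in place of hydrogen on an aromatic carbon, a chloro in place of hydrogen on an aromatic carbon, para to a large group. For the measured compounds named here, no measured pair shows this change alone, so the expectation is only a small shift toward stronger inhibition, none beyond the scatter. The estimated change is a 1.4-fold lower number from compound 2 to compound 3 (0.15 log units; within the scatter). For compound 3 the expected value is 900 nM, with an estimated range of 350 nM to 2000 nM.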

Compound 3, half-maximal inhibitory concentration: 1080 nM
Estimate against measurement, compound 3: 1.2-fold (0.08 log units) below; the measured number falls inside the stated range.
By their numbers in this assay, from the lowest: compounds 3, 1 and 2 (each within the scatter of the next).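

In this assay, chloro in place of hydrogen on an aromatic carbon, para to a large group, gives a 1.2-fold lower number from compound 2 to compound 3 (0.07 log units; within the scatter) and the matching bromo change gives a 1.2-fold lower number from compound 1 to compound 3 (0.07 log units; within the scatter) in the same series. Compound 3 carries both halogens, so each change can now be read alone, and neither step leaves the scatter. Nothing measured here explains these steps. As far as these compounds go, whether an amine, a methoxy or a carboxylic acid at this place would give a step beyond the scatter stays open. So does the standing of the compound with hydrogen at both places.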